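This account rests on a few compounds, and the source may have more. Where it says the series, first, only, none or still open, it means among the compounds named here.

Measured in an ADME assay on J744 cells (Mus musculus) for cytotoxicity, read by MTT assay, with a stated time of 48 h (on this read-out higher numbers stand for weaker inhibition and lower numbers for stronger inhibition), each entry being a limit:
- compound 1 `Cc1c(C(=O)N/N=C/c2ccco2)no[n+]1[O-]` gives > 400000 nM (a limit)
- compound 2 `Cc1c(C(=O)N/N=C/c2cccs2)no[n+]1[O-]` gives > 400000 nM (a limit)
- compound 3 `Cc1c(C(=O)N/N=C/c2ccc(C(=O)O)cc2)no[n+]1[O-]` gives > 400000 nM (a limit)

Compound 2 has no number on this scale, only the limit > 400000 nM as its entry. The other two compounds fare the same, with the limit of > 400000 nM in this assay, at which 3 of the 3 values shown sit, describing the whole set.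

Compound 4 `Cc1c(C(=O)N/N=C/c2ccc([N+](=O)[O-])s2)no[n+]1[O-]` keeps the shared core and differs from compound 2 by nitro in place of hydrogen on an aromatic carbon, next to the ring sulfur (nitro in place of hydrogen on an aromatic carbon). Going by the values given here, the one measured step is a step that the two limits leave unreadable from compound 1 to compound 2 and it exchanges one ring for another, so it offers no size to carry over. Among the compounds with values here, no measured compound carries a nitro group, and the direction is therefore an open expectation. Any readable value for compound 4 would have to lie on the stronger side of the limit held by compound 2 (> 400000 nM). The estimated step (an at least 1.6-fold lower number from compound 2 to compound 4 (0.20 log units; that floor lies within the scatter)) is modest and uncertain, and a result at the limit again is just as likely. Compound 4 is expected at 250000 nM within an estimated range (60000 nM to 400000 nM).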

Compound 4, half-maximal inhibitory concentration: 68000 nM
For compound 4 the middle estimate is 3.7-fold (0.57 log units) above the measured one, and the stated range covers the measured number.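

Nitro in place of hydrogen on an aromatic carbon, next to the ring sulfur, is the first change here to yield a readable number in this assay, with an at least 5.8-fold lower number from compound 2 to compound 4 (0.76 log units; beyond the scatter). From the compounds shown here alone, compound 2 holds only a limit, so this step is a floor and its full size remains unknown. The earlier compounds gave no sign that any change could move the read-out off the limit, and compound 4 now stands alone with a number: the limit of > 400000 nM in this assay, at which 3 of the 4 values shown sit.

The compounds shown leave open whether an amine or a chlorine atom on the same aromatic carbon would also give a readable number. They also leave open whether nitro would give a similar step at another carbon of this ring or on the ring of compound 1.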